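Aryl thioether swap on a cinnamamide benzamide series

The source may hold more compounds than are shown below. What is called first, only, known or untested is meant among the compounds shown, and "the series" means these compounds.

Measured compounds:
Compound 1 `Nc1ccccc1NC(=O)c1ccc(CSc2nccc(C(F)(F)F)n2)cc1` gives 66.1% in a functional assay on SMMC-7721 cells (Homo sapiens) for inhibition, read by CCK-8 assay, with a stated time of 72 h, tested at 2 uM; on this read-out higher numbers stand for more inhibition of growth at the one concentration tested and lower numbers for less inhibition of growth.
Compound 2 `Nc1ccccc1NC(=O)c1ccc(CSc2ccc(Br)cc2)cc1` gives 10% in this assay.
Compound 3 `Nc1ccccc1NC(=O)/C=C/c1ccc(CSc2ccc(F)cc2)cc1` gives 18.3% in this assay.

Compound 3 holds the second highest of the three numbers. Its nearest neighbour is compound 2, whose number lies within the usual scatter of it, so the two cannot be told apart. Its furthest neighbour is compound 1, which stands well beyond the scatter above compound 3.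

Compound 4 `Cc1cc(C)cc(SCc2ccc(/C=C/C(=O)Nc3ccccc3N)cc2)c1` differs from compound 3 in one place: 3,5-dimethylphenyl in place of 4-fluorophenyl on a sulfur. For the measured compounds named here, no step between measured compounds isolates such a change, so there is nothing to show how exchanging one aryl group on the sulfur for another moves the read-out; the only comparisons that exist mix several changes at once. The step of a number 1.7 percentage points higher from compound 3 to compound 4 (within the scatter) is therefore expected to be small and not beyond the scatter, in no firm direction. Compound 4 is expected to give about 20%, with a range from 5% to 40%.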

Compound 4, percent growth inhibition at one concentration: 8.61%
Compound 4: middle estimate off by 11.4 percentage points, on the high side; the range from low to high includes it.
By their numbers in this assay, from the lowest: compounds 4, 2 and 3 (each within the scatter of the next); then compound 1.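

In this assay, for the compounds shown here, the exchange of 4-fluorophenyl for 3,5-dimethylphenyl on a sulfur gives the first step that changes one place only, a number 9.7 percentage points lower from compound 3 to compound 4 (within the scatter). This step stays within the scatter, so the assay does not tell these two aryl groups apart on the core they share, and this change shows no firm effect at this position. No measurement at hand bears on what lies behind this result.

As far as these compounds go, whether an amine or a carboxylic acid on the aryl group at this sulfur would carry the read-out beyond the scatter remains open. Also open, from the compounds shown here alone, is whether the same exchange of 4-fluorophenyl for 3,5-dimethylphenyl would read alike on the core of compound 1.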